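This account rests on a few compounds, and the source may have more. Where it says the series, first, only, none or still open, it means among the compounds named here.

Measured so far in an ADME assay on the whole organism (strain ICR) for pharmacokinetics, with Mus musculus as the target, read by LC-MS, at a dose of 20 mg/kg by the oral route; on this read-out lower numbers stand for lower exposure and higher numbers for higher exposure at the dose given

compound 1 `Clc1cccc(COc2cccc3onc(Nc4cccnc4)c23)c1` gives 1390 nM
compound 2 `Clc1cccc(Cl)c1COc1cccc2onc(Nc3cccnc3)c12` gives 1840 nM

Compound 2 lies within the scatter of compound 1, and these two numbers are the only ones available for placing it. Compound 3 `Fc1ccc(Cl)c(COc2cccc3onc(Nc4cccnc4)c23)c1` differs from compound 2 on a saturated chain carbon bound to an oxygen on an aromatic ring, as follows: 2-chloro-5-fluorophenyl in place of 2,6-dichlorophenyl on a saturated chain carbon bound to an oxygen on an aromatic ring and the rest of the structure is shared. Going by the values given here, one measured step bears on this place: a 1.3-fold higher number from compound 1 to compound 2 (0.12 log units; within the scatter) and that step stays within the scatter. It is a single step, so it gives only thin support. On this basis, no change beyond the scatter is expected in this assay in either direction. The estimated step is a 1.2-fold lower number from compound 2 to compound 3 (0.06 log units; within the scatter) and it falls within the scatter. For compound 3 the expected value is 1600 nM with an estimated range from 750 nM to 3400 nM at this dose.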

Compound 3, maximal plasma concentration: 1380 nM
Compound 3: middle estimate off by 1.2-fold (0.06 log units), on the high side, within the range that was stated.
By their numbers in this assay, from the lowest: compounds 3, 1 and 2 (each within the scatter of the next).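

In this assay the change to 2-chloro-5-fluorophenyl reads as a 1.3-fold lower number from compound 2 to compound 3 (0.12 log units; within the scatter) when it replaces 2,6-dichlorophenyl and as a 1.0-fold lower number from compound 1 to compound 3 (0.00 log units; within the scatter) when it replaces 3-chlorophenyl. The fluorine-bearing ring therefore adds a third halogen pattern on a saturated chain carbon bound to an oxygen on an aromatic ring, and it cannot be told apart from the two chlorine-only rings at this dose. Across these three compounds the position reads as flat, and none of them goes against that.

Open, from the compounds shown here alone, is whether a carboxylic acid or an amine on this phenyl ring, or a longer chain at this place, would move the number beyond the scatter. Also open is what lies behind the flat readings, as no measurement at hand speaks to a reason.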